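The source may hold more compounds than are shown below. What is called first, only, known or untested is meant among the compounds shown, and "the series" means these compounds.

Measured in a functional assay on PC-3 cells (Homo sapiens) for cytotoxicity, read by MTT assay, with stated times of 48 h and 4 h; on this read-out lower numbers stand for stronger inhibition and higher numbers for weaker inhibition:
Compound 1 `O=[N+]([O-])c1ccc(/C=C/c2nc(NCCN3CCCCC3)c3ccccc3n2)cc1` gives 25600 nM
Compound 2 `CCN(CC)CCCNc1nc(/C=C/c2ccc([N+](=O)[O-])cc2)nc2ccccc12` gives 15400 nM
Compound 3 `NCCCCNc1nc(/C=C/c2ccc([N+](=O)[O-])cc2)nc2ccccc12` gives 4530 nM

Compound 3 stands lowest of the three, and both of its gaps lie beyond the scatter: a 3.4-fold lower number from compound 2 to compound 3 (0.53 log units; beyond the scatter) and a 5.7-fold lower number from compound 1 to compound 3 (0.75 log units; beyond the scatter). Compound 4 `NCCCCNc1nc(/C=C/c2ccc([N+](=O)[O-])cc2)nc2ccc(Cl)cc12` alters it in one place, with chloro in place of hydrogen on an aromatic carbon. Among the measured compounds shown here, all the measured steps change the side chain, the largest being modest, so they bear on this change only indirectly. For the measured compounds named here, no measured step shows what chloro does on the shared core. No step beyond the scatter is therefore expected in this assay, and neither direction is favoured. The expected step is a 1.1-fold lower number from compound 3 to compound 4 (0.05 log units; within the scatter). Compound 4 is estimated at 4000 nM, with an expected range from 1500 nM to 11000 nM.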

Compound 4, half-maximal inhibitory concentration: > 100000 nM
Compound 4: a limit, no number; the forecaster's own chance of this, stated with the estimate: 3%; at least 25-fold (1.39 log units) between middle value and limit.
By their numbers in this assay, from the lowest: compound 3; then compounds 2 and 1 (each within the scatter of the next). At a limit, above all of these: compound 4.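

In this assay, chloro in place of hydrogen on an aromatic carbon of the shared core gives an at least 22-fold higher number from compound 3 to compound 4 (1.34 log units; beyond the scatter). As far as these compounds go, compound 4 gives > 100000 nM, a limit and not a number, so the full size of this step stays unknown. Among the compounds shown here, the earlier steps changed only the side chain and were modest at most, so this is the first sign that the shared core is far less tolerant of change at this position.

From the compounds shown here alone, whether fluoro, methoxy or an amine at this position would have the same effect remains open. So does whether chloro would act alike with the side chains of compound 1 and compound 2.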